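Trifluoromethyl in Place of Fluoro on the Shared Core

This account rests on a few compounds, and the source may have more. Where it says the series, first, only, none or still open, it means among the compounds named here.

Compound 3 `COC(=O)[C@@]1(C)CCC=C2[C@@H]1CC[C@@H](C)[C@]2(C)Cc1c(C)[nH]c2ccc(F)cc12` gives 11000 nM in a functional assay on HeLa cells (Homo sapiens) for inhibition, read by sulforhodamine B assay, with a stated time of 48 h; a lower number here means a stronger inhibitor of growth, a higher number a weaker inhibitor of growth. Its two neighbours carry other halogens at the same aromatic carbon: compound 1 `COC(=O)[C@@]1(C)CCC=C2[C@@H]1CC[C@@H](C)[C@]2(C)Cc1c(C)[nH]c2ccc(Br)cc12` gives 11000 nM, and compound 2 `COC(=O)[C@@]1(C)CCC=C2[C@@H]1CC[C@@H](C)[C@]2(C)Cc1c(C)[nH]c2ccc(Cl)cc12` gives 12000 nM. The steps among them are small: a 1.1-fold higher number from compound 1 to compound 2 (0.04 log units; within the scatter), no change at the digits printed from compound 1 to compound 3 (within the scatter) and a 1.1-fold lower number from compound 2 to compound 3 (0.04 log units; within the scatter). Compound 3 therefore stands level with compound 1 and within the scatter of compound 2.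

Compound 4 `COC(=O)[C@@]1(C)CCC=C2[C@@H]1CC[C@@H](C)[C@]2(C)Cc1c(C)[nH]c2ccc(C(F)(F)F)cc12` differs from compound 3 in one place: trifluoromethyl in place of fluoro on an aromatic carbon. For the measured compounds named here, the three measured steps bear on this change only in part, since each of them exchanges one halogen for another at this carbon and none reached beyond the scatter, while no measured step brings in a trifluoromethyl group. On that basis compound 4 is expected to show no step beyond the scatter, with no change at the digits printed from compound 3 to compound 4 (within the scatter) as the estimated change. In this assay compound 4 is estimated at 11000 nM, with a range from 4000 nM to 30000 nM.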

Compound 4, concentration for 50% growth inhibition: 12000 nM
Compound 4: the middle estimate sits 1.1-fold (0.04 log units) below what was measured; low and high end bracket the measured number.
By their numbers in this assay, from the lowest: compounds 1, 3, 2 and 4 (each within the scatter of the next).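

In this assay the steps of a 1.1-fold higher number from compound 3 to compound 4 (0.04 log units; within the scatter) and no change at the digits printed from compound 2 to compound 4 (within the scatter) and a 1.1-fold higher number from compound 1 to compound 4 (0.04 log units; within the scatter) all stay within the scatter. The earlier compounds shown here showed this only for exchanges of one halogen for another, whereas here trifluoromethyl, with 4 heavy atoms, reads level with fluoro, chloro and bromo on this aromatic carbon, so no group among the four separates from the others at this position. Nothing measured here explains why the position reads so flat.

The compounds shown leave open whether a different kind of group on this carbon, such as an amine, a carboxylic acid or a longer alkyl chain, would give a step beyond the scatter. They also leave open whether the same flat reading would hold on a core other than the shared one.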